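The source may report more compounds than this note shows. Statements on the series, on what has been measured and on what is new or still open speak of the compounds shown alone.

Measured compounds in this series:

compound 1 `O=c1ccc(-c2ccccc2)nn1CCCCNC(=S)Nc1ccc(Cl)cc1` — in a functional assay on the whole organism (stomach) with Rattus norvegicus as the target (on this read-out lower numbers stand for an effect already at smaller amounts and higher numbers for an effect only at larger amounts of compound), compound 1 gives > 100 mg/kg, which is a limit of the assay and not a number.
compound 2 `O=c1ccc(-c2ccccc2)nn1CCCCNC(=S)Nc1ccccc1` — in this assay compound 2 gives > 100 mg/kg, again a limit.
compound 3 `CCC/N=C(/NC#N)NCCCCn1nc(-c2ccccc2)ccc1=O` — in this assay compound 3 gives > 100 mg/kg, also a limit.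

Compound 2 therefore stands at a limit, and the two further values shown are limits as well (the limit of > 100 mg/kg in this assay, at which 3 of the 3 values shown sit). The step from compound 1 to compound 2, hydrogen in place of chloro on an aromatic carbon, is a step that the two limits leave unreadable from compound 1 to compound 2. The step from compound 2 to compound 3, a non-ring group of five carbons and three nitrogens in place of a phenyl-bearing thiourea group on the amine nitrogen, is a step that the two limits leave unreadable from compound 2 to compound 3. Neither step gives a readable size.

Compound 4 `O=c1ccc(-c2ccccc2)nn1CCCCNC(=S)Nc1cccc2ccccc12` differs from compound 2 by naphthalen-1-yl in place of phenyl on an amide-type nitrogen. Among the compounds with values here, no measured step touches this change, and the two steps that exist both run between limits. Nothing in the series shows a shift beyond the scatter, so no shift beyond the scatter is expected in this assay either; the likeliest outcome is a further limit. Compound 4 is estimated at 150 mg/kg, within 60 mg/kg to 400 mg/kg, which means an expected step that the limit leaves unreadable from compound 2 to compound 4.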

Compound 4, dose for half-maximal effect: > 100 mg/kg
Compound 4: a limit, no number (the forecaster's own chance of this, stated with the estimate: 80%); the middle value does not contradict the limit.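

In this assay compound 4 gives > 100 mg/kg, a limit and not a number. No size can be read for the steps from compound 1 or compound 2 to compound 4, since all the values sit at the same limit: the limit of > 100 mg/kg in this assay, at which 4 of the 4 values shown sit. The compounds shown leave open what naphthalen-1-yl in place of phenyl does to the dose for half-maximal effect.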